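A few compounds are considered here, and "the series" means these few. Any claim that something is new, unique, unknown or untested is made for them only; others in the source may bear on it.

Compound 1, `Cc1cccc(-n2nncc2CN2C(=O)C3(C(C#N)=C(N)Oc4c(N)cc5nc6ccccc6nc5c43)c3ccccc32)c1`: in a functional assay on HepG2 cells (Homo sapiens) for antiproliferative activity, read by MTT assay, with a stated time of 48 h (on this read-out higher numbers stand for weaker inhibition and lower numbers for stronger inhibition), compound 1 gives > 50000 nM, which is a limit of the assay and not a number.
Compound 2, `CCc1cccc(C)c1-n1nncc1CN1C(=O)C2(C(C#N)=C(N)Oc3c(N)cc4nc5ccccc5nc4c32)c2ccccc21`: in this assay compound 2 gives > 50000 nM, which is again a limit of the assay.

Going by the values given here, compound 2 therefore stands at the limit, with no measured number of its own, and the same is true of the one compound it is paired with. The step that the two limits leave unreadable from compound 1 to compound 2 cannot be sized because the limit of > 50000 nM in this assay, at which 2 of the 2 values shown sit, covers both of its ends.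

Compound 3, `CCc1cccc(CC)c1-n1nncc1CN1C(=O)C2(C(C#N)=C(N)Oc3c(N)cc4nc5ccccc5nc4c32)c2ccccc21`, differs from compound 2 by methyl in place of hydrogen on a saturated chain carbon bound to an aromatic carbon. Among the compounds with values here, the only measured step that bears on this change is the one from compound 1 to compound 2, and that step is unreadable; nothing measured points to a gain or loss in this assay beyond the scatter. Compound 3 is accordingly expected to sit at the limit as well, with an estimate of 100000 nM and a range from 30000 nM to 300000 nM. The step that the limit leaves unreadable from compound 2 to compound 3 that this estimate implies is expected to be none beyond the scatter.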

Compound 3, half-maximal inhibitory concentration: 16500 nM
Compound 3: middle estimate off by 6.1-fold (0.78 log units), on the high side, outside the stated range (below it).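

In this assay, adding one methyl on a saturated chain carbon bound to an aromatic carbon, which turns 2-ethyl-6-methylphenyl into 2,6-diethylphenyl, gives an at least 3.0-fold lower number from compound 2 to compound 3 (0.48 log units; beyond the scatter). The wider change from 3-methylphenyl to 2,6-diethylphenyl on the aromatic nitrogen gives an at least 3.0-fold lower number from compound 1 to compound 3 (0.48 log units; beyond the scatter), so this substituent can move the read-out off the limit, which the earlier pair could not show. Both steps give only a minimum size because each starts from a limit and not from a number: the limit of > 50000 nM in this assay, at which 2 of the 3 values shown sit.

The compounds shown leave open whether the trend continues or stops at ethyl, as a propyl chain in place of ethyl would test. They also leave open how far a single methyl change reaches when the starting value is a measured number, and whether a methoxy group in place of ethyl would have a similar effect.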